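A few compounds are considered here, and "the series" means these few. Any claim that something is new, unique, unknown or untested is made for them only; others in the source may bear on it.

Compound 1 `CN1CCC(N(C)C(=O)C2CN(S(=O)(=O)c3ccccc3)c3ccccc32)CC1` gives 316 nM in a functional assay on CHO cells for antagonist activity at 5-hydroxytryptamine receptor 6 (Homo sapiens), read by FLIPR; on this read-out higher numbers stand for weaker inhibition and lower numbers for stronger inhibition. Among the compounds with values here, compound 2 `CN1CCC(N(C)C(=O)C2CN(S(=O)(=O)c3ccc(OC(F)(F)F)cc3)c3ccccc32)CC1` gives 20 nM in this assay, and the single one-point step recorded so far, a 16-fold lower number from compound 1 to compound 2 (1.20 log units; beyond the scatter), introduced trifluoromethoxy in place of hydrogen on an aromatic carbon. Within the data shown here, compound 2 therefore holds the lower of the two numbers, with compound 1 the only neighbour, at a substantially higher value.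

Compound 3 `CN1CCC(N(C)C(=O)C2CN(S(=O)(=O)c3ccc(-c4ccccc4)cc3)c3ccccc32)CC1` carries phenyl in place of trifluoromethoxy on an aromatic carbon. Among the measured compounds shown here, no measured step exchanges one substituent for another at that carbon; the only bearing step, a 16-fold lower number from compound 1 to compound 2 (1.20 log units; beyond the scatter), shows that occupying this position with a group is what lowers the number. Phenyl keeps the position occupied, so compound 3 is expected to stay close to compound 2, with a step of a 1.5-fold higher number from compound 2 to compound 3 (0.18 log units; within the scatter) expected to lie within or near the scatter. Compound 3 is estimated at 30 nM, in the range 8 nM to 120 nM.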

Compound 3, inhibition constant: 126 nM
Compound 3: the middle estimate sits 4.2-fold (0.62 log units) below what was measured, and the stated range ends below it.
By their numbers in this assay, from the lowest: compound 2; then compound 3; then compound 1.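

Occupation of this position is not sufficient on its own: in this assay, a 6.3-fold higher number from compound 2 to compound 3 (0.80 log units; beyond the scatter) shows that the identity of the group on this aromatic carbon, para to a large group, matters as well. Phenyl still gives a lower number than hydrogen, with a 2.5-fold lower number from compound 1 to compound 3 (0.40 log units; beyond the scatter), but this is a smaller step than a 16-fold lower number from compound 1 to compound 2 (1.20 log units; beyond the scatter), so only part of the shift seen with trifluoromethoxy is retained. Nothing available explains why these two groups differ.

With only hydrogen, trifluoromethoxy and phenyl shown at this carbon, the compounds leave open whether the higher number of compound 3 goes with the aromatic ring or with the loss of the oxygen and fluorine atoms. A methoxy group, a chlorine atom or an amine at the same carbon would help to separate these readings.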